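This account rests on a few compounds, and the source may have more. Where it says the series, first, only, none or still open, it means among the compounds named here.

In a functional assay on HT-29 cells (Homo sapiens) for cytotoxicity, read by sulforhodamine B assay (on this read-out lower numbers stand for higher toxicity in this test and higher numbers for lower toxicity in this test), three compounds sharing one core differ only in their aromatic group. Compound 1 `CC1=CC[C@@H]([C@@](C)(O)CCCC(C)(C)NC(=S)N/N=C\c2ccccc2)CC1`, whose ring carries no added group, gives 57400 nM. Compound 2 `COc1ccc(/C=N\NC(=S)NC(C)(C)CCC[C@](C)(O)[C@@H]2CC=C(C)CC2)cc1` gives > 100000 nM, which is a limit and not a number. Compound 3 `CC1=CC[C@@H]([C@@](C)(O)CCCC(C)(C)NC(=S)N/N=C\c2ccc(N(C)C)cc2)CC1` gives > 100000 nM, also only a limit. Compound 3 therefore stands at the limit of > 100000 nM in this assay, at which 2 of the 3 values shown sit.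

Compound 4 `CC1=CC[C@@H]([C@@](C)(O)CCCC(C)(C)NC(=S)N/N=C\c2cccc([N+](=O)[O-])c2)CC1` has 3-nitrophenyl in place of 4-(dimethylamino)phenyl on a carbon with a double bond to nitrogen.

Among the compounds with values here, three measured steps bear on this change, though none involves a nitro group. They are an at least 1.7-fold higher number from compound 1 to compound 2 (0.24 log units; that floor lies within the scatter), an at least 1.7-fold higher number from compound 1 to compound 3 (0.24 log units; that floor lies within the scatter) and a step that the two limits leave unreadable from compound 2 to compound 3. None of them shows a change of readable size beyond the scatter. Within the data shown here, the only actual number so far belongs to compound 1 at 57400 nM, so a modest move towards lower numbers is expected. Compound 4 may still stop at the limit. The estimated step is an at least 1.5-fold lower number from compound 3 to compound 4 (0.18 log units; that floor lies within the scatter). For compound 4 the expected value is 65000 nM, with an estimated range from 30000 nM to 100000 nM.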

Compound 4, concentration lethal to 50% of the cells: > 100000 nM
Compound 4 ended at the assay's limit (the forecaster's own chance of this, stated with the estimate: 45%); at least 1.5-fold (0.18 log units) between middle value and limit.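

In this assay, compound 4 shows that a 3-nitrophenyl group, unlike the two 4-substituted rings tested earlier, also gives no number, and it joins compound 2 and compound 3 at the limit: the limit of > 100000 nM in this assay, at which 3 of the 4 values shown sit.

Only compound 1, with no added ring group, goes against this pattern and has a true number. Within the data shown here, the one readable step is an at least 1.7-fold higher number from compound 1 to compound 4 (0.24 log units; that floor lies within the scatter), so nitro in place of hydrogen gives only a floor that does not pass the usual scatter, while the steps from compound 2 and compound 3 to compound 4 cannot be read, since both ends are limits.

On these data alone, how far compound 2, compound 3 and compound 4 lie past the limit stays open. Also open, as far as these compounds go, is whether a ring bearing chlorine, a carboxylic acid or a primary amine would give a readable number, and how such a number would compare with compound 1 at 57400 nM.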